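Amide to Urea on a Shared Core: Expected Growth Inhibition

This account rests on a few compounds, and the source may have more. Where it says the series, first, only, none or still open, it means among the compounds named here.

Measured compounds:
compound 1, `O=C(Nc1cccc(-n2cc(-c3ccncc3)c(-c3ccc(Cl)c(O)c3)n2)c1)Nc1cccc(C(F)(F)F)c1`, 4340 nM
compound 2, `COc1cc(-c2nn(-c3cccc(NC(=O)c4cccc(C(F)(F)F)c4)c3)cc2-c2ccncc2)ccc1Cl`, 27900 nM

Of the compounds shown here, two have been measured in a functional assay on UACC-257 cells (Homo sapiens) for inhibition, read by sulforhodamine B assay, with a stated time of 48 h; a higher number here means a weaker inhibitor of growth, a lower number a stronger inhibitor of growth. Compound 1 gives 4340 nM, while compound 2 gives 27900 nM, the higher of the two numbers; the gap between them lies beyond the usual scatter. Compound 1 and compound 2 differ in more than one place, so their comparison does not isolate a single change.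

Compound 3, `COc1cc(-c2nn(-c3cccc(NC(=O)Nc4cccc(C(F)(F)F)c4)c3)cc2-c2ccncc2)ccc1Cl`, has not yet been measured. It differs from compound 2 in one place: (3-(trifluoromethyl)phenyl)amino in place of 3-(trifluoromethyl)phenyl on a carbonyl carbon. The amide linker of compound 2 thus becomes a urea linker in compound 3, the same linker that compound 1 carries.

Among the measured compounds shown here, no single-change step between measured compounds is available to guide the expectation. Still, compound 1, the urea bearer, sits at the lower number, 4340 nM, so a move toward lower numbers is expected for compound 3, of moderate size, a 3.1-fold lower number from compound 2 to compound 3 (0.49 log units; beyond the scatter). Compound 3 is estimated at 9000 nM, with a range from 2500 nM to 30000 nM.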

Compound 3, concentration for 50% growth inhibition: 923 nM
Beside the measured number, compound 3's estimate is 9.8-fold (0.99 log units) above it; measured number outside the range, below it.
By their numbers in this assay, from the lowest: compound 3; then compound 1; then compound 2.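

In this assay, replacing 3-(trifluoromethyl)phenyl with (3-(trifluoromethyl)phenyl)amino on the carbonyl carbon gives a 30-fold lower number from compound 2 to compound 3 (1.48 log units; beyond the scatter). Among the compounds shown here, this is the first reading of the amide-to-urea change on its own, with the rest of the molecule held constant, and it shows that growth inhibition is highly sensitive to the linker at this position. Compound 3 also isolates a second change, methyl in place of hydrogen on an oxygen on an aromatic ring, which gives a 4.7-fold lower number from compound 1 to compound 3 (0.67 log units; beyond the scatter), so among these urea compounds the methyl ether carries the lower number.

The compounds shown leave open whether the gain depends on the hydrogen-bond donor that enters with the urea nitrogen, a question that a urea with a methyl group on that nitrogen or a carbamate linker could address, and whether a larger group such as ethyl on the oxygen would extend the second step. Nothing available here explains why either change lowers the number.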